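The source may hold more compounds than are shown below. What is called first, only, known or untested is meant among the compounds shown, and "the series" means these compounds.

Measured so far in a functional assay on the whole organism for inhibition, with Mus musculus as the target, at a dose of 25 mg/kg by the oral route; on this read-out higher numbers stand for more inhibition at the one dose given (going by the name of the read-out) and lower numbers for less inhibition:

Compound 1, `Clc1ccc(N2CCN(CCCOc3ccc4c(c3)CCC4)CC2)cc1`: 58%
Compound 2, `FC(F)(F)c1cccc(N2CCN(CCCOc3ccc4c(c3)CCC4)CC2)c1`: 73%

Compound 1 stands lowest of the two numbers in this assay. For the measured compounds named here, its only neighbour, compound 2, sits higher by a gap that lies beyond the usual scatter of the measurement. Going by the values given here, the two compounds differ in more than one place, so no single step between them is on record; all that can be said is what their two values show, namely that compound 2 gives the higher reading.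

Compound 3, `O=[N+]([O-])c1ccc(N2CCN(CCCOc3ccc4c(c3)CCC4)CC2)cc1`, has not yet been measured in this assay. It comes from compound 1 by the change (nitro in place of chloro on an aromatic carbon). Among the compounds with values here, nothing among the measured compounds carries a nitro group, so there is no directly comparable step to lean on. The expected step of a number 4 percentage points higher from compound 1 to compound 3 (within the scatter) is therefore a small one, upward if anything, and within the scatter of the method. For compound 3 the estimated reading in this assay is 62%, with a range from 42% to 80%.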

Compound 3, a percentage reported as inhibition, in the whole organism at one dose (the size of the read-out at that dose, not a potency): 26%
Compound 3: middle estimate off by 36 percentage points, on the high side, outside the stated range (below it).
By their numbers in this assay, from the lowest: compound 3; then compound 1; then compound 2.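

In this assay, the series now has its first step at a single place: nitro in place of chloro on an aromatic carbon, para to a large group, gives a number 32 percentage points lower from compound 1 to compound 3 (beyond the scatter). The earlier pair differed in more than one place, so it could not show that this position is sensitive to what it carries; this step shows that, with the rest of compound 1 unchanged, exchanging this one group is enough to move the reading beyond the usual scatter. Nothing measured here accounts for the size or direction of the step.

From the compounds shown here alone, with one step at this position, it remains open whether the lower reading is particular to nitro or would also appear with other groups there, such as an amine, a nitrile or a carboxylic acid. Going by these compounds, it is also open whether a plain phenyl ring would read closer to compound 1 or to compound 3, and whether a longer chain in the shared core would leave the step from chloro to nitro unchanged.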